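Replacing pyrrolidin-1-yl with 1H-imidazol-1-yl in compound 2

This account rests on a few compounds, and the source may have more. Where it says the series, first, only, none or still open, it means among the compounds named here.

Going by the values given here, only two compounds have numbers so far in a functional assay on the whole organism for agonist activity, with Mus musculus as the target; on this read-out higher numbers stand for an effect only at larger amounts of compound and lower numbers for an effect already at smaller amounts. Compound 1 (`CC(=O)N(C)CC#CCn1ccnc1`) gives 1.4 mg/kg. Compound 2 (`Cn1ccn(CC#CCN2CCCC2)c1=O`) gives 6.6 mg/kg, the higher number of the two, so it needs a larger dose for the same effect, and the gap lies beyond the usual scatter. These two compounds differ in more than one place, so their gap cannot be tied to any single change.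

Compound 3 (`Cn1ccn(CC#CCn2ccnc2)c1=O`) has not yet been measured. It carries 1H-imidazol-1-yl in place of pyrrolidin-1-yl on a saturated chain carbon bound to a triple-bonded carbon. Among the compounds with values here, no measured pair shows this change alone, so any forecast is uncertain. Compound 1 also carries 1H-imidazol-1-yl on such a carbon and gives 1.4 mg/kg, which tilts the expectation slightly towards a lower number. The expected result is a 1.7-fold lower number from compound 2 to compound 3 (0.22 log units; within the scatter), a step that would stay within the scatter. Compound 3 is estimated at 4 mg/kg, with an expected range of 1 mg/kg to 20 mg/kg.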

Compound 3, dose for half-maximal effect: 4.4 mg/kg
Estimate against measurement, compound 3: 1.1-fold (0.04 log units) below; the measured number falls inside the stated range.
By their numbers in this assay, from the lowest: compound 1; then compounds 3 and 2 (each within the scatter of the next).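

Going by these compounds alone, this pair shows the change on its own for the first time: in this assay, putting 1H-imidazol-1-yl in place of pyrrolidin-1-yl on a saturated chain carbon bound to a triple-bonded carbon gives a 1.5-fold lower number from compound 2 to compound 3 (0.18 log units; within the scatter). On the core shared by these two compounds, the read-out therefore does not separate the two groups, even though one is a five-membered non-aromatic ring and the other a five-membered aromatic ring with a second ring nitrogen. No measured evidence here speaks to why the two groups read alike.

The compounds shown leave open whether a group of a different kind at this place, such as the open-chain dimethylamino group or the larger piperidin-1-yl ring, would also stay within the scatter of these two numbers. Going by these compounds, it is also open whether the same exchange would read the same way on another core, which would take the pyrrolidin-1-yl counterpart of compound 1, whose 1H-imidazol-1-yl group sits on the same kind of carbon.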